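Sulfonylurea series: bicyclic amine replaced by hexyl chain

A few compounds are considered here, and "the series" means these few. Any claim that something is new, unique, unknown or untested is made for them only; others in the source may bear on it.

Measured so far in a functional assay on the whole organism (blood) with Rattus norvegicus as the target, with stated times of 24 h and 1 h, at a dose of 5 mg/kg by the intraperitoneal route; a higher number here means a stronger effect of the compound at the dose given, a lower number a weaker effect:
compound 1 `COc1ccc(Cl)cc1C(=O)NCC1CCN(S(=O)(=O)NC(=O)NC2CCCCC2)CC1` gives 20%
compound 2 `COc1ccc(Cl)cc1C(=O)NCC1CCN(S(=O)(=O)NC(=O)NC[C@@H]2C[C@@H]3C=C[C@@H]2C3)CC1` gives 15%

Compound 2 and compound 1 sit within the scatter of each other in this assay; the only step shown, a number 5 percentage points lower from compound 1 to compound 2 (within the scatter), exchanges the ring groups on the amide-type nitrogen without a change beyond the scatter.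

Compound 3 `CCCCCCNC(=O)NS(=O)(=O)N1CCC(CNC(=O)c2cc(Cl)ccc2OC)CC1` is not yet measured. It differs from compound 2 by a group of 5 heavy atoms (5 carbon; no ring) in place of a group of 7 heavy atoms (7 carbon; 2 five-membered non-aromatic rings of carbon only), on a saturated chain carbon bound to an amide-type nitrogen. Going by the values given here, the one step that bears on this change is the ring exchange from compound 1 to compound 2, and that step lay within the scatter. With a single such comparison, and no step beyond the scatter anywhere in the series, no change beyond the scatter is expected in this assay for compound 3, so a number 2 percentage points higher from compound 2 to compound 3 (within the scatter) is the expected step. Compound 3 is therefore estimated at 17%, with a range from 5% to 30%.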

Compound 3, a percentage reported as activity, at one dose (the size of the read-out at that dose, not a potency): 17%
Estimate against measurement, compound 3: no gap at the digits printed; the measured number falls inside the stated range.
By their numbers in this assay, from the lowest: compounds 2, 3 and 1 (each within the scatter of the next).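

In this assay, going by these compounds alone, the step of a number 3 percentage points lower from compound 1 to compound 3 (within the scatter) is the first comparison of a ring and an open chain on the amide-type nitrogen, with hexyl in place of cyclohexyl, and it stays within the scatter. The step of a number 2 percentage points higher from compound 2 to compound 3 (within the scatter) also stays within the scatter, with pentyl replacing a group of two five-membered carbon rings, one double bond and 3 defined stereocentres on a saturated chain carbon bound to an amide-type nitrogen, so across these compounds neither ring type nor open chain separates from the others in this read-out. No measurement bears on why these exchanges leave the read-out within the scatter.

Still open, from the compounds shown here alone, is whether a phenyl ring, a longer chain such as dodecyl, or a chain ending in an amine or a carboxylic acid would move the read-out beyond the scatter. A single dose also leaves open whether the effect of these compounds would be stronger or weaker at other doses.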